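The source may hold more compounds than are shown below. What is called first, only, known or untested is meant among the compounds shown, and "the series" means these compounds.

Working notes on the series. Four compounds are compared in a functional assay on A549 cells (Homo sapiens) for inhibition, with a stated time of 72 h; on this read-out lower numbers stand for stronger inhibition and higher numbers for weaker inhibition: compound 1 `CC(C)[C@H]1CC[C@@]2(CO2)[C@H]2C(=O)OCC(C(=O)O)=C[C@H]12`, compound 2 `CC(C)[C@H]1CC[C@@](O)(CO)[C@H]2C(=O)OCC(C(=O)O)=C[C@H]12`, compound 3 `CNC(=O)C1=C[C@@H]2[C@@H](C(C)C)CC[C@@]3(CO3)[C@H]2C(=O)OC1` and compound 4 `CNC(=O)C1=C[C@@H]2[C@@H](C(C)C)CC[C@@](O)(CO)[C@H]2C(=O)OC1`, the last of which is not yet measured.

Compound 1 gives 458 nM in this assay. Compound 3 gives 5540 nM in this assay. The structural difference between them is methylamino in place of hydroxy on a carbonyl carbon, and the resulting step of a 12-fold higher number from compound 1 to compound 3 (1.08 log units; beyond the scatter) is large. For compound 2 this assay reports only a limit, > 32000 nM, and not a number. That the limit is reached is itself part of the record (the limit of > 32000 nM in this assay, at which 1 of the 3 values shown sits). How the core of compound 2 differs from the core of compound 1 is not broken down here.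

Compound 4 differs from compound 2 by methylamino in place of hydroxy on a carbonyl carbon, the same change that separates compound 3 from compound 1, made at a place described in the same words. Within the data shown here, with only one measured instance of this change, the expectation for compound 4 rests on that single step: the same change already weakened inhibition from compound 1 to compound 3 a 12-fold higher number from compound 1 to compound 3 (1.08 log units; beyond the scatter), and compound 2 sits at the limit of this assay. Compound 4 is therefore expected to move by about a step that the limit leaves unreadable from compound 2 to compound 4 in this assay, most likely again returning only a limit. The estimate for compound 4 is 150000 nM in this assay, with a range from 32000 nM to 600000 nM.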

Compound 4, half-maximal inhibitory concentration: > 32000 nM
Compound 4 gave a limit, no number (the forecaster's own chance of this, stated with the estimate: 90%); the middle value is on the limit's open side.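

Compound 4 returns only a limit in this assay, > 32000 nM, and compound 2 also has only a limit there, so no step can be read between compound 2 and compound 4: the limit of > 32000 nM in this assay, at which 2 of the 4 values shown sit.

The compounds shown leave open whether methylamino in place of hydroxy on a carbonyl carbon changes inhibition on the core of compound 2 as it does on the core of compound 1.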